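The source may hold more compounds than are shown below. What is called first, only, known or untested is meant among the compounds shown, and "the series" means these compounds.

Compound 1 `CN1CCN(c2ccc(S(=O)(=O)Oc3cccc(Cl)c3)cc2)C1=O`: 2100 nM
Compound 2 `CCN1CCN(c2ccc(S(=O)(=O)Oc3cccc(Cl)c3)cc2)C1=O`: 6800 nM

For the measured compounds named here, in a functional assay on HT-29 cells (Homo sapiens) for antiproliferative activity, read by sulforhodamine B assay, with a stated time of 48 h (on this read-out lower numbers stand for stronger inhibition and higher numbers for weaker inhibition), compound 2 stands at the higher of the two numbers; its only neighbour is compound 1, and the step of a 3.2-fold higher number from compound 1 to compound 2 (0.51 log units; beyond the scatter) separates them. Compound 3 `CCN1CCN(c2ccc(S(=O)(=O)Oc3ccc(OC)cc3)cc2)C1=O` differs from compound 2 by 4-methoxyphenyl in place of 3-chlorophenyl on an oxygen. Going by the values given here, no measured step concerns this part of the molecule, and the one known step, a 3.2-fold higher number from compound 1 to compound 2 (0.51 log units; beyond the scatter), alters a different position, so it offers no guide to direction. The expected step is therefore no change at the digits printed from compound 2 to compound 3 (within the scatter), with wide uncertainty. Compound 3 is estimated at 6800 nM, between 1500 nM and 30000 nM.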

Compound 3, half-maximal inhibitory concentration: 60000 nM
Beside the measured number, compound 3's estimate is 8.8-fold (0.95 log units) below it; measured number above the stated range.
By their numbers in this assay, from the lowest: compound 1; then compound 2; then compound 3.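

The group on the oxygen bound to the sulfonyl sulfur clearly matters: in this assay, putting 4-methoxyphenyl in place of 3-chlorophenyl gives an 8.8-fold higher number from compound 2 to compound 3 (0.95 log units; beyond the scatter). This single step changes both the substituent and where it sits on the ring, so the two changes cannot be told apart. No available measurement explains the weaker inhibition. Still open, on these data alone, is how 3-methoxyphenyl or 4-chlorophenyl would behave on this oxygen, as each would change only one of those two features.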